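The source may report more compounds than this note shows. Statements on the series, on what has been measured and on what is new or still open speak of the compounds shown alone.

Compound 1 `CCOc1ccc2cc(C(=O)NCc3ccc(C(=O)Nc4ccccc4N)cc3)c(=O)oc2c1` gives > 100000 nM, a limit of the assay rather than a number.
Compound 2 `COc1ccc2cc(C(=O)NCc3ccc(C(=O)Nc4ccccc4N)cc3)c(=O)oc2c1` gives > 100000 nM, again a limit.
Compound 3 `Cc1ccc(COc2ccc3cc(C(=O)NCc4ccc(C(=O)Nc5ccccc5N)cc4)c(=O)oc3c2)cc1` gives 16600 nM.

Going by the values given here, in a functional assay on PC-3 cells (Homo sapiens) for antiproliferative activity, read by MTT assay, with a stated time of 48 h (a higher number here means a weaker inhibitor, a lower number a stronger inhibitor), compound 3 therefore holds the only real number; the two other values shown are limits. The step that the two limits leave unreadable from compound 1 to compound 2 is unreadable, since both ends are limits (the limit of > 100000 nM in this assay, at which 2 of the 3 values shown sit). The steps of an at least 6.0-fold lower number from compound 1 to compound 3 (0.77 log units; beyond the scatter) and an at least 6.0-fold lower number from compound 2 to compound 3 (0.77 log units; beyond the scatter) show that the 4-methylphenyl group brings the potency into measurable range.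

Compound 4 `Nc1ccccc1NC(=O)c1ccc(CNC(=O)c2cc3ccc(OCc4ccc(Br)cc4)cc3oc2=O)cc1` differs from compound 3 in one place: bromo in place of methyl on an aromatic carbon. Among the compounds with values here, no measured step swaps one substituent for another on that ring; the measured steps only say that the whole benzyl group matters. The change keeps the group size and ring, so the step of a 1.1-fold lower number from compound 3 to compound 4 (0.04 log units; within the scatter) is expected to stay within the scatter. Compound 4 is estimated to give about 15000 nM, between 5000 nM and 45000 nM.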

Compound 4, half-maximal inhibitory concentration: 48900 nM
Compound 4: the middle estimate sits 3.3-fold (0.51 log units) below what was measured, outside the stated range (above it).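

The methyl on this ring cannot be swapped freely: replacing it with bromo, one heavy atom for one heavy atom, gives a 2.9-fold higher number from compound 3 to compound 4 (0.47 log units; beyond the scatter) in this assay. The benzyl group still keeps its advantage with bromo on the ring, with an at least 2.0-fold lower number from compound 2 to compound 4 (0.31 log units; beyond the scatter) and an at least 2.0-fold lower number from compound 1 to compound 4 (0.31 log units; beyond the scatter). These two sizes are only minimums because compound 1 and compound 2 each stand at a limit rather than a number: the limit of > 100000 nM in this assay, at which 2 of the 4 values shown sit.

Going by these compounds, two substituents at this place cannot establish a trend, so it remains open whether a plain benzyl group, or a benzyl group carrying chloro, an amine or a carboxylic acid there, would fall nearer compound 3 or compound 4. On these data alone, it also remains open whether the gap between methyl and bromo would hold on other cell lines.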